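The compounds below may be only part of what the source reports. "The series", "measured", "known", "first", "only" and "open" are said of these compounds alone.

For the measured compounds named here, compound 1, `CCC(C(=O)NCc1ccccc1Cl)N1C(=O)CCC1=O`, is one of only two compounds so far measured in a functional assay on the whole organism (strain Albino Swiss CD1) with Mus musculus as the target, in the maximal electroshock model; on this read-out higher numbers stand for an effect only at larger amounts of compound and lower numbers for an effect already at smaller amounts. In this assay compound 1 gives 113 mg/kg, the highest of the two numbers. Going by the values given here, its only neighbour, compound 2, `CCC(C(=O)NCc1ccc(Cl)cc1)N1C(=O)CCC1=O`, gives 95.4 mg/kg in this assay, and the step of a 1.2-fold lower number from compound 1 to compound 2 (0.07 log units; within the scatter) leaves both compounds inside the usual scatter, so neither can be set above the other. The unmeasured compound 3, `CCC(C(=O)NCc1ccccc1C(F)(F)F)N1C(=O)CCC1=O`, keeps the core of compound 1 and alters a single group: trifluoromethyl in place of chloro on an aromatic carbon. Among the compounds with values here, no measured step exchanges one kind of group for another on that ring; the sole step available, from compound 1 to compound 2, exchanges one chlorophenyl group for another and does not move the number beyond the scatter. That step bears only loosely on the new change, and it offers no sign of a large move in either direction in this assay. The estimate for compound 3 therefore amounts to a step of a 1.0-fold lower number from compound 1 to compound 3 (0.01 log units; within the scatter), expected to stay within the scatter. Compound 3 is expected to give about 110 mg/kg in this assay, with a range from 55 mg/kg to 220 mg/kg.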

Compound 3, dose for half-maximal effect: > 150 mg/kg
Compound 3: only a limit was reported; the forecaster's own chance of this, stated with the estimate: 10%; middle value at least 1.3-fold (0.13 log units) away from the limit.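

For compound 3, this assay gives a limit of the assay and not a number: the limit of > 150 mg/kg in this assay, at which 1 of the 3 values shown sits. Trifluoromethyl in place of chloro, on an aromatic carbon ortho to a large group, is the first change shown that puts one kind of group in place of another on this ring, whereas the earlier step only exchanged one chlorophenyl group for another, and it gives an at least 1.3-fold higher number from compound 1 to compound 3 (0.12 log units; that floor lies within the scatter). Only a floor is available for this step and that floor does not clear the scatter, so the change cannot yet be told apart from it, although the step has no upper end and its true size may be larger.

The compounds shown leave open whether a measured number for compound 3 would carry the step beyond the scatter, and how trifluoromethyl would read on the ring carbon that bears chloro in compound 2. They also leave open what fluoro, methoxy or an amine would give on the same aromatic carbon, and whether any group there would produce an effect already at smaller amounts of compound.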